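Benzoyl Replaces Vinyl: What the Limits Allow Us to Expect

This account rests on a few compounds, and the source may have more. Where it says the series, first, only, none or still open, it means among the compounds named here.

Three close relatives sharing one core have been tested in a functional assay on MKN-45 cells (Homo sapiens) for cytotoxicity, read by MTT assay, with a stated time of 48 h; on this read-out higher numbers stand for weaker inhibition and lower numbers for stronger inhibition. Compound 1 `C#CCSc1nnc(C)n1N1C(=O)c2ccccc2C1=O` reached only the limit of the assay, giving > 200000 nM. Compound 2 `C=CCSc1nnc(CC)n1N1C(=O)c2ccccc2C1=O` likewise stopped at the limit, with > 200000 nM. Compound 3 `C=CCSc1nnc(CCC)n1N1C(=O)c2ccccc2C1=O` also stands at the limit, > 200000 nM, so no number is known for it. Within the data shown here, the only step among the measured compounds, a step that the two limits leave unreadable from compound 2 to compound 3, is one that the two limits leave unreadable. The whole picture so far is the limit of > 200000 nM in this assay, at which 3 of the 3 values shown sit: every value sits at the same limit.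

Compound 4 `CCCc1nnc(SCC(=O)c2ccccc2)n1N1C(=O)c2ccccc2C1=O` differs from compound 3 by benzoyl in place of vinyl on a saturated chain carbon bound to a sulfur. Cut one bond further out, the same change reads allyl to benzoylmethyl. Among the measured compounds shown here, no measured step resembles this change, and the single measured step is unreadable, so the data give no direction or size for it. Compound 4 is therefore expected to remain near the limit, and the step of an at least 1.3-fold lower number from compound 3 to compound 4 (0.12 log units; that floor lies within the scatter) is an estimate rather than an observation. In this assay compound 4 is estimated at 150000 nM, within a range from 30000 nM to 400000 nM.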

Compound 4, half-maximal inhibitory concentration: > 200000 nM
Compound 4 ended at the assay's limit; the forecaster's own chance of this, stated with the estimate: 60%; at least 1.3-fold (0.12 log units) between middle value and limit.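

Compound 4, like compound 3, gives only a limit in this assay, so no step can be read between them. The whole set now stands as follows: the limit of > 200000 nM in this assay, at which 4 of the 4 values shown sit. The compounds shown leave open whether any change to the groups on the shared core gives a measurable value in this assay, and how far apart these compounds truly lie.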